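The compounds below may be only part of what the source reports. "The series", "measured", "known", "first", "only" and "open" are said of these compounds alone.

Measured so far in a physicochemical assay for solubility, read by spectrophotometry; on this read-out lower numbers stand for lower solubility and higher numbers for higher solubility (all three are limits, not numbers):
- Compound 1 `O=C(Nc1ccc(C(F)(F)F)cc1)c1cc(Cl)ccc1O` gives < 100000 nM as a limit
- Compound 2 `O=C(c1ccccc1)c1ccc(NC(=O)c2cc(Cl)ccc2O)cc1` gives < 50000 nM as a limit
- Compound 3 `O=C(c1ccccc1)c1ccc(NC(=O)c2cc(Br)ccc2O)cc1` gives < 50000 nM as a limit

Compound 2 therefore stands at a limit, with no number of its own. Compound 4 `CCCNC(=O)Oc1ccc(Cl)cc1C(=O)Nc1ccc(C(=O)c2ccccc2)cc1` carries one change from it, hydroxy to (propylcarbamoyl)oxy: propylcarbamoyl in place of hydrogen on an oxygen on an aromatic ring and nothing else differs. Two measured steps lie nearest, benzoyl in place of trifluoromethyl in a step that the two limits leave unreadable from compound 1 to compound 2 and bromo in place of chloro in a step that the two limits leave unreadable from compound 2 to compound 3 and neither has a readable size. Neither step changes that oxygen either, so they give no guide to size or direction. The expected step is a step that the limit leaves unreadable from compound 2 to compound 4 with no change beyond the usual scatter foreseen. For compound 4 the estimate is 30000 nM with an expected range of 8000 nM to 50000 nM and a report as a limit is likely.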

Compound 4, solubility: < 50000 nM
Compound 4: only a limit was reported; the forecaster's own chance of this, stated with the estimate: 80%; the middle value does not contradict the limit.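

Within the data shown here, compound 4 gives < 50000 nM, a limit and not a number, and compound 2 also has only a limit, so no step between them can be read. The compounds shown leave open how large the change in this assay is, and in which direction it runs, when propylcarbamoyl replaces hydrogen on that oxygen.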